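Replacing the free hydroxy of compound 2

A few compounds are considered here, and "the series" means these few. Any claim that something is new, unique, unknown or untested is made for them only; others in the source may bear on it.

In a functional assay on HCT-116 cells (Homo sapiens) for antiproliferative activity, read by sulforhodamine B assay, with a stated time of 48 h (on this read-out higher numbers stand for weaker inhibition and lower numbers for stronger inhibition), compound 1 (`COc1cc(O)c(C(=O)/C=C/c2cccc(Cl)c2Cl)c(OC)c1`) gives 2700 nM, compound 2 (`COc1cccc(/C=C/C(=O)c2c(O)cc(OC)cc2OC)c1`) gives 3100 nM and compound 3 (`COc1cc(O)c(C(=O)/C=C/c2cccc(OC)c2OC)c(OC)c1`) gives 3500 nM. These three numbers lie within the usual scatter of one another, so compound 2 cannot be told apart from the other two.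

Compound 4 (`COc1cccc(/C=C/C(=O)c2c(OC)cc(OC)cc2OCC=C(C)C)c1`) has not yet been measured. Its structure departs from that of compound 2 in one place: 3-methylbut-2-en-1-yl in place of hydrogen on an oxygen on an aromatic ring. Put another way, hydroxy becomes (3-methylbut-2-en-1-yl)oxy, so the free hydroxy carried by all three measured compounds is gone.

Within the data shown here, only one measured step bears on this, and only loosely: a 1.1-fold higher number from compound 2 to compound 3 (0.05 log units; within the scatter). It adds a methoxy on an aromatic carbon, not a group on that oxygen. Among the measured compounds shown here, no measured compound lacks the hydroxy, so the direction of any change remains unknown. The expected step is modest, a 1.1-fold higher number from compound 2 to compound 4 (0.05 log units; within the scatter), with no shift beyond the scatter anticipated. For compound 4 the estimated value is 3500 nM, within an expected range of 1000 nM to 12000 nM.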

Compound 4, half-maximal inhibitory concentration: 7700 nM
Estimate against measurement, compound 4: 2.2-fold (0.34 log units) below; measured number inside the range.
By their numbers in this assay, from the lowest: compounds 1, 2 and 3 (each within the scatter of the next); then compound 4.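

In this assay, the change from hydroxy to (3-methylbut-2-en-1-yl)oxy gives a 2.5-fold higher number from compound 2 to compound 4 (0.40 log units; beyond the scatter), so inhibition weakens. This oxygen on an aromatic ring is therefore a place where a change can be read, unlike the earlier methoxy on an aromatic carbon, which gave only a 1.1-fold higher number from compound 2 to compound 3 (0.05 log units; within the scatter). No measurement shown here accounts for the weaker inhibition.

From the compounds shown here alone, what stays open is whether the shift comes from losing the free hydroxy or from the particular chain that enters. A methyl on the same oxygen, a saturated 3-methylbutyl chain or a chain ending in an amine would help separate these two readings, as each removes the hydroxy but brings a different group.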